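Maximal response at the amine nitrogen of the piperidine ring

A few compounds are considered here, and "the series" means these few. Any claim that something is new, unique, unknown or untested is made for them only; others in the source may bear on it.

Measured compounds:
- compound 1 `CC(C)(C)OC(=O)N1CCC(Oc2ncnc3c2CCN3c2ccc(S(C)(=O)=O)cc2F)CC1`: 139%
- compound 2 `CC(C)S(=O)(=O)N1CCC(Oc2ncnc3c2CCN3c2ccc(S(C)(=O)=O)cc2F)CC1`: 62%

Compound 1 and compound 2 share one core and differ only in the group on an amine nitrogen in a ring. In a functional assay on CHO-K1 cells with Glucose-dependent insulinotropic receptor (Homo sapiens) as the target, read by a luciferase reporter, with a stated time of 5 h (on this read-out lower numbers stand for smaller maximal responses and higher numbers for larger maximal responses), compound 1 gives 139% and compound 2 gives 62%. For the measured compounds named here, compound 2 stands lowest of the two numbers; the one step measured so far, a number 77 percentage points lower from compound 1 to compound 2 (beyond the scatter), is the only guide to how this position behaves, and it shows that a change here can shift the maximal response by a large amount.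

Compound 3 `CC(C)c1noc(N2CCC(Oc3ncnc4c3CCN4c3ccc(S(C)(=O)=O)cc3F)CC2)n1` carries a further change at the same position: 3-isopropyl-1,2,4-oxadiazol-5-yl in place of isopropylsulfonyl on an amine nitrogen in a ring. Going by the values given here, no measured pair covers this exchange, so its size and direction cannot be taken from the data; only the large movement seen from compound 1 to compound 2 says that a sizeable step in either direction is plausible. The maximal response of compound 3 in this assay is therefore expected near 95%, with a wide range from 45% to 145%, which means an expected step of a number 33 percentage points higher from compound 2 to compound 3 (beyond the scatter).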

Compound 3, largest response reached (reported as percent of maximum), in percent of the reference or control that the assay uses: 124%
Beside the measured number, compound 3's estimate is 29 percentage points below it; low and high end bracket the measured number.
By their numbers in this assay, from the lowest: compound 2; then compound 3; then compound 1.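

In this assay, 3-isopropyl-1,2,4-oxadiazol-5-yl in place of isopropylsulfonyl on the amine nitrogen gives a number 62 percentage points higher from compound 2 to compound 3 (beyond the scatter), so this position can move the maximal response up as well as down, and an isopropyl group on the substituent does not by itself hold the response low. A high response also does not depend on tert-butoxycarbonyl, although the two groups are not equivalent, with a number 15 percentage points lower from compound 1 to compound 3 (beyond the scatter), and the isopropylsulfonyl group of compound 2 is the one that stands apart in this set of three. No supporting data bear on why the three groups rank in this way.

Still open, on these data alone, is whether the low response follows the sulfonyl link itself or its pairing with isopropyl, a question that methylsulfonyl or cyclopropylsulfonyl on the same nitrogen would address. Also open, as far as these compounds go, is how much the response of compound 3 rests on the oxadiazole ring rather than on its substituent, which a tert-butyl or methyl group on that ring, or a pyrimidine ring on the nitrogen, would help to separate.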